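Chain-shortened analog in the lipoxygenase series

The compounds below may be only part of what the source reports. "The series", "measured", "known", "first", "only" and "open" are said of these compounds alone.

Measured compounds:
compound 1, `CCCCCCCCCCCCCC1=CC(=O)C=C(OC)C1=O`, 1050 nM
compound 2, `CCCCCC1=CC(=O)C=C(OC)C1=N`, 1010 nM
compound 3, `CCCCCCCCCCCCCCCc1cc(O)cc(OC)c1O`, 140 nM

In an assay on isolated protein for inhibition of Polyunsaturated fatty acid 5-lipoxygenase (Homo sapiens), read by ELISA, with a stated time of 10 min (on this read-out higher numbers stand for weaker inhibition and lower numbers for stronger inhibition), compound 3 gives 140 nM, the lowest number of the three; compound 2 at 1010 nM and compound 1 at 1050 nM both sit well beyond the scatter above it, so compound 3 counts as the strongest inhibitor among the measured set. Compounds 1 and 2 differ from each other in both chain and core, so no single change can be read from their pair, and they offer no clean guide to the chain alone.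

Compound 4, `CCCCCCCCCCCc1cc(O)cc(OC)c1O`, keeps the core of compound 3 and differs only in the chain: hydrogen in place of butyl on a saturated chain carbon, ten or more bonds along the chain from an aromatic carbon. For the measured compounds named here, no measured pair isolates this change. With the core held constant and the shared ring substituents unchanged, a modest step is expected, if any, toward weaker inhibition, likely within or close to the scatter. The step from compound 3 to compound 4 is estimated as a 1.6-fold higher number from compound 3 to compound 4 (0.20 log units; within the scatter). Compound 4 is expected to give 220 nM, within 70 nM to 700 nM.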

Compound 4, half-maximal inhibitory concentration: 280 nM
Compound 4: middle estimate off by 1.3-fold (0.10 log units), on the low side; the measured number falls inside the stated range.
By their numbers in this assay, from the lowest: compounds 3 and 4 (each within the scatter of the next); then compounds 2 and 1 (each within the scatter of the next).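

For the compounds shown here, the step of a 2.0-fold higher number from compound 3 to compound 4 (0.30 log units; within the scatter) in this assay is the first reading that isolates the chain with the core held constant. Hydrogen in place of butyl on a saturated chain carbon removes 4 carbon atoms and leaves the two compounds within the scatter of each other, so this change at this position does not separate them on this read-out. No accompanying measurement bears on this result.

Still open, on these data alone, is whether a much shorter chain or a longer chain on this core would stay within the scatter of these two compounds. Also open, as far as these compounds go, is how an amine or a carboxylic acid in place of butyl at this position would read.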